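The compounds below may be only part of what the source reports. "The series", "measured", "known", "first", "only" and "open" are said of these compounds alone.

Measured compounds in an assay on mitochondria (strain BALB/c) for inhibition of glycerol-3-phosphate acyltransferase 1, mitochondrial (Mus musculus), read by scintillation counting, with a stated time of 10 min; on this read-out lower numbers stand for stronger inhibition and higher numbers for weaker inhibition:
Compound 1, `CCCCCCCCS(=O)(=O)Nc1cc(-c2ccccc2-c2ccccc2)ccc1C(=O)O`, gives 17100 nM.
Compound 2, `CCCCCCCCS(=O)(=O)Nc1cc(-c2ccccc2OC)ccc1C(=O)O`, gives 16100 nM.
Compound 3, `CCCCCCCCS(=O)(=O)Nc1ccc(-c2ccccc2-c2ccccc2)cc1C(=O)O`, gives 10100 nM.

Of the compounds shown here, three have been measured in this assay, and a fourth, compound 4, `CCCCCCCCS(=O)(=O)Nc1ccc(-c2ccccc2OC)cc1C(=O)O`, has not. Compound 1 and compound 2 share a core and differ in one place: methoxy in place of phenyl on an aromatic carbon. That change made a 1.1-fold lower number from compound 1 to compound 2 (0.03 log units; within the scatter). Compound 3 has the same atoms as compound 1 joined differently; the difference between the two cores is not broken down here. Compound 3 and compound 2 stand within the scatter of each other, as do compound 3 and compound 1.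

Compound 4 is related to compound 3 by the same change that relates compound 2 to compound 1: methoxy in place of phenyl on an aromatic carbon. Because that change made a 1.1-fold lower number from compound 1 to compound 2 (0.03 log units; within the scatter), the expectation for compound 4 is a step of about the same size, a 1.1-fold lower number from compound 3 to compound 4 (0.03 log units; within the scatter), read as a small shift that stays within the usual scatter. On that basis compound 4 is estimated at 9500 nM in this assay, with a likely range from 4000 nM to 22000 nM.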

Compound 4, half-maximal inhibitory concentration: 27600 nM
The estimate for compound 4 lay 2.9-fold (0.46 log units) below the measured number; measured number above the stated range.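

In this assay, methoxy in place of phenyl on an aromatic carbon, ortho to a large group, gave a 2.7-fold higher number from compound 3 to compound 4 (0.44 log units; beyond the scatter), and this step does not match the one seen for the same change on the other core: the same change on two cores in this assay, a 1.1-fold lower number (0.03 log units; within the scatter) from compound 1 to compound 2 and a 2.7-fold higher number (0.44 log units; beyond the scatter) from compound 3 to compound 4, 2.9-fold (0.46 log units) apart, beyond the scatter of two such steps For these two pairs, then, the change does not carry from one core to the other as a fixed step, and its outcome depends on which of the two cores bears it. The pairs do not show what in the rearrangement of atoms between the cores lies behind the gap, nor how the change would behave on any further core.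

As far as these compounds go, it remains open whether a group such as an amine or a hydroxyl in place of the phenyl would show the same split between the two cores. Also open, from the compounds shown here alone, is whether a longer chain in place of the present alkyl chain would alter the size of either step.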